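Hydroxy in place of piperidin-1-yl on the shared core

The source may hold more compounds than are shown below. What is called first, only, known or untested is meant among the compounds shown, and "the series" means these compounds.

Compound 1 `CC(C)(C)Nc1nc(N)c(C(=O)N=C(N)N)nc1Cl`: 48%
Compound 2 `NC(N)=NC(=O)c1nc(Cl)c(N2CCCCC2)nc1N`: 85%

In an assay for inhibition of acid-sensing ion channel 3 (Homo sapiens), read by patch clamp, tested at 20 uM (a higher number here means more inhibition at the concentration tested (going by the name of the read-out), a lower number less inhibition), compound 1 gives 48% and compound 2 gives 85%, the highest of the two numbers. Within the data shown here, the single measured step, a number 37 percentage points higher from compound 1 to compound 2 (beyond the scatter), is the only one bearing on compound 3 `NC(N)=NC(=O)c1nc(Cl)c(O)nc1N`, whose change is hydroxy in place of piperidin-1-yl on an aromatic carbon. That step shows the read-out moving strongly with the group at this place, but the hydroxy resembles neither group measured, so the guide is rough. A downward step, a number 60 percentage points lower from compound 2 to compound 3 (beyond the scatter), beyond the scatter is expected. Compound 3 is expected at 25%, within 5% to 55%.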

Compound 3, a percentage reported as inhibition, at one concentration (the size of the read-out at that concentration, not a potency): 9%
For compound 3 the middle estimate is 16 percentage points above the measured one, within the range that was stated.
By their numbers in this assay, from the lowest: compound 3; then compound 1; then compound 2.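

In this assay hydroxy in place of piperidin-1-yl gives a number 76 percentage points lower from compound 2 to compound 3 (beyond the scatter), and hydroxy in place of (tert-butyl)amino gives a number 39 percentage points lower from compound 1 to compound 3 (beyond the scatter). Hydroxy therefore falls below both earlier groups at this position, and the order runs hydroxy, (tert-butyl)amino, piperidin-1-yl, with every step beyond the scatter. Nothing at hand explains this loss. Still open, from the compounds shown here alone, is whether the high number of compound 2 depends on the piperidine ring itself or on any carbon-bearing group here; morpholin-4-yl, methoxy or a plain amino group at this place would help separate these readings.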